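The source may hold more compounds than are shown below. What is called first, only, known or untested is meant among the compounds shown, and "the series" means these compounds.

Of the compounds shown here, three have been measured in an in vitro functional assay on HEK285-7 cells for antagonist activity at prostaglandin D2 receptor 2 (Homo sapiens), read by BRET and beta-arrestin recruitment; a lower number here means a smaller maximal response, a higher number a larger maximal response. Compound 1 `CCC(c1ccccc1)c1nc(-c2ccc(Cl)cc2)c(CC(=O)O)s1` gives 50%, the lowest of the three numbers. Compound 2 `O=C(O)Cc1sc(C(c2ccc(F)cc2)c2ccc(F)cc2)nc1-c1ccccc1` gives 80%, and compound 3 `CS(=O)(=O)Nc1cccc(-c2nc(C(c3ccc(F)cc3)c3ccc(F)cc3)sc2CC(=O)O)c1` gives 80%. For the measured compounds named here, both stand a clear distance above compound 1, beyond the scatter, while the single measured step, no change at the digits printed from compound 2 to compound 3 (within the scatter), brings no change within the scatter.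

Compound 4 `O=C(O)Cc1sc(C(Cc2ccccc2)c2ccccc2)nc1-c1ccc(Cl)cc1` is reached from compound 1 by one change: phenyl in place of methyl on a saturated chain carbon, two bonds along the chain from two aromatic carbons. Going by the values given here, no measured step touches this position on the saturated chain carbon; the only measured step, from compound 2 to compound 3, sits on an aromatic carbon elsewhere and does not bear on it. What the two higher numbers of compound 2 and compound 3 show is that compounds carrying two aromatic rings on that carbon reached the larger maximal response, whereas compound 1 with its smaller group did not.

On that thin basis a moderate rise is expected, with wide uncertainty, so the step of a number 12 percentage points higher from compound 1 to compound 4 (beyond the scatter) is an estimate rather than a measured change. Compound 4 is expected to give about 62%, somewhere between 40% and 85%.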

Compound 4, largest response reached (reported as efficacy), in percent of the reference or control that the assay uses: 50%
Estimate against measurement, compound 4: 12 percentage points above; low and high end bracket the measured number.
By their numbers in this assay, from the lowest: compounds 1 and 4 (each within the scatter of the next); then compounds 2 and 3 (each within the scatter of the next).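

For the compounds shown here, the first measured step at this saturated chain carbon, no change at the digits printed from compound 1 to compound 4 (within the scatter), shows that in this assay the swap of methyl for phenyl leaves the maximal response within the scatter, even though six heavy atoms and a further aromatic ring enter where one carbon leaves. Read one bond further out, as ethyl to benzyl, the change gives the same result: on the core of compound 1, this position accepts a much larger carbon-only group with no measurable shift. Nothing available explains why the number holds steady under this swap.

Compounds 2 and 3 differ from compound 1 in more than one place, so what separates them from it remains unresolved. Going by these compounds, it also remains open whether a hydroxyl or an amine on this carbon, or a longer chain such as phenethyl in place of benzyl, would move the response.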